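A few compounds are considered here, and "the series" means these few. Any claim that something is new, unique, unknown or untested is made for them only; others in the source may bear on it.

Working notes on the series. Compound 1 `COc1c(Br)cccc1C(=O)Nc1ccc(Sc2nc3ccccc3s2)c(Cl)c1` was run in an ADME assay on HEK293 cells (Homo sapiens) for cytotoxicity, read by reporter gene assay and resazurin assay, with a stated time of 48 h; a lower number here means that less compound is tolerated, a higher number that more compound is tolerated. In this assay compound 1 gives only a limit, > 100000 nM. Compound 2 `COc1c(Br)cccc1C(=O)Nc1ccccc1` likewise gives only a limit in this assay, > 100000 nM. Among the compounds with values here, compound 1 therefore stands at the limit of this assay, where both values shown sit (the limit of > 100000 nM in this assay, at which 2 of the 2 values shown sit); nothing in the numbers places it apart from compound 2, and no step between two measured compounds is available to carry forward.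

Compound 3 `O=C(Nc1ccc(Sc2nc3ccccc3s2)c(Cl)c1)c1cc(Br)cc(Br)c1`, not yet measured, differs from compound 1 in one place (a group of 8 heavy atoms (6 carbon, 2 bromine; one six-membered aromatic ring of carbon only) in place of a group of 9 heavy atoms (7 carbon, 1 oxygen, 1 bromine; one six-membered aromatic ring of carbon only), on a carbonyl carbon). Within the data shown here, with both measured values sitting at the limit, there is no measured step on which to build, and the expectation for this assay is that compound 3 is tolerated to the same extent as compound 1. The expected step is a number no higher from compound 1 to compound 3 (the limit leaves the size open), that is, none beyond the scatter. Compound 3 is expected at 100000 nM, with a range from 50000 nM to 200000 nM, most likely reported again only as a limit.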

Compound 3, half-maximal cytotoxic concentration: > 100000 nM
Compound 3: only a limit was reported; the forecaster's own chance of this, stated with the estimate: 85%; the middle value lies on the limit itself.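

Compound 1 and compound 3 both give only limits in this assay, so no step can be read between them: the limit of > 100000 nM in this assay, at which 3 of the 3 values shown sit. The compounds shown leave open at what concentration any of them becomes cytotoxic to these cells, and whether the 3,5-dibromophenyl group of compound 3 makes any difference to that concentration.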